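This account rests on a few compounds, and the source may have more. Where it says the series, first, only, none or still open, it means among the compounds named here.

Compound 1 `CNC(=O)Nc1cc(Oc2cncc(OC)c2)c([C@H]2COCC[C@@H]2F)cn1` and compound 2 `CNC(=O)Nc1cc(Oc2cncc(OC)c2)c(C2=CCOCC2)cn1` share a core and differ only in the saturated ring on the aromatic carbon. In an ADME assay on the whole organism (Rattus norvegicus) for pharmacokinetics, at a dose of 0.5 mg/kg by the intravenous route (on this read-out lower numbers stand for slow clearance and higher numbers for fast clearance), compound 1 gives 26.7 mL/min/kg and compound 2 gives 41.7 mL/min/kg. Going by the values given here, the step of a 1.6-fold higher number from compound 1 to compound 2 (0.19 log units; within the scatter) is the only comparison so far, and it leaves compound 2 standing alongside compound 1 in this assay, the two numbers being within the usual scatter of each other.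

Among the compounds with values here, compound 3 `CNC(=O)Nc1cc(Oc2cncc(OC)c2)c(C2CCOCC2)cn1` keeps the core and again changes only this ring: a group of 6 heavy atoms (5 carbon, 1 oxygen; one six-membered non-aromatic ring with 1 hetero atom) in place of a group of 6 heavy atoms (5 carbon, 1 oxygen; one six-membered non-aromatic ring with 1 hetero atom), on an aromatic carbon. Within the data shown here, the one step that bears on it, the change from compound 1 to compound 2 at the same position, moved this assay by a 1.6-fold higher number from compound 1 to compound 2 (0.19 log units; within the scatter), which is within the scatter. On that basis the step from compound 2 to compound 3 is expected to be a 1.2-fold lower number from compound 2 to compound 3 (0.06 log units; within the scatter), that is, no change beyond the scatter. Compound 3 is therefore estimated at 36 mL/min/kg in this assay, with a range from 20 mL/min/kg to 65 mL/min/kg.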

Compound 3, clearance: 46.7 mL/min/kg
The estimate for compound 3 lay 1.3-fold (0.11 log units) below the measured number; low and high end bracket the measured number.
By their numbers in this assay, from the lowest: compounds 1, 2 and 3 (each within the scatter of the next).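

Taking away the double bond outside aromatic rings, with oxan-4-yl as the group that enters, gives a 1.1-fold higher number from compound 2 to compound 3 (0.05 log units; within the scatter) in this assay, so this ring change on the aromatic carbon does not move clearance beyond the scatter. Oxan-4-yl in place of 4-fluorooxan-3-yl, which removes the fluorine and moves the ring's point of attachment, gives a 1.7-fold higher number from compound 1 to compound 3 (0.24 log units; within the scatter), so all three groups at this position remain within the scatter of one another. Nothing at hand accounts for these numbers or bears on what lies behind them.

On these data alone, it remains open whether an amine, a carboxylic acid or a longer chain in place of oxan-4-yl would give a step beyond the scatter. The compounds shown also leave open how clearance responds to changes elsewhere on the shared core, such as at the (methylcarbamoyl)amino group.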